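Cyclohexyl in place of an aromatic ring at the amine

This account rests on a few compounds, and the source may have more. Where it says the series, first, only, none or still open, it means among the compounds named here.

Compound 1 `COc1cc(N)c(Cl)cc1NC(=O)C1CCN(Cc2ccc(Cl)cc2)CC1` gives 1.2 mg/kg in a functional assay on the whole organism for antagonist activity, with Mus musculus as the target; a higher number here means that more compound is needed for the effect, a lower number that less compound is needed.
Compound 2 `CCOc1ccc(CN2CCC(C(=O)Nc3cc(Cl)c(N)cc3OC)CC2)cc1` gives 6.3 mg/kg in this assay.
Compound 3 `COc1cc(N)c(Cl)cc1NC(=O)C1CCN(Cc2ccccc2F)CC1` gives > 4 mg/kg in this assay; this is a limit of the assay and not a number, (the limit of > 4 mg/kg in this assay, at which 1 of the 3 values shown sits).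

Of the two numbers, compound 2 stands highest, meaning more of it is needed: a 5.3-fold higher number from compound 1 to compound 2 (0.72 log units; beyond the scatter), the change being ethoxy in place of chloro on an aromatic carbon. Compound 4 `COc1cc(N)c(Cl)cc1NC(=O)C1CCN(CC2CCCCC2)CC1` has not been measured. It differs from compound 2 by cyclohexyl in place of 4-ethoxyphenyl on a saturated chain carbon bound to an amine nitrogen in a ring. Within the data shown here, two measured steps touch the same place. The first: an at least 3.3-fold higher number from compound 1 to compound 3 (0.52 log units; beyond the scatter). The second: a step that the limit leaves unreadable from compound 2 to compound 3. Both earlier changes at this carbon either raised the number or left the outcome unreadable, and neither introduced a six-membered non-aromatic ring, so the direction for compound 4 cannot be read from them directly. On these data alone, compound 2 already sits at the weak end, and a move into a ring without hydrogen-bond acceptors is untested here, so the expectation for compound 4 is a number near that of compound 2, a step of no change at the digits printed from compound 2 to compound 4 (within the scatter) that is expected to stay roughly within the scatter, with a real chance that only a limit is returned. The estimate for compound 4 in this assay is 6.3 mg/kg, expected to lie between 2 mg/kg and 20 mg/kg.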

Compound 4, dose for half-maximal effect: 2.9 mg/kg
Compound 4: the middle estimate sits 2.2-fold (0.34 log units) above what was measured; the range from low to high includes it.
By their numbers in this assay, from the lowest: compound 1; then compound 4; then compound 2.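

Cyclohexyl shows that an aromatic ring is not required on this saturated chain carbon: in this assay the change from 4-ethoxyphenyl gives a 2.2-fold lower number from compound 2 to compound 4 (0.34 log units; beyond the scatter). The ring type alone does not set the order, since cyclohexyl does not match 4-chlorophenyl, with a 2.4-fold higher number from compound 1 to compound 4 (0.38 log units; beyond the scatter), so compound 4 falls between two compounds that both carry an aromatic ring at this place. The comparison with the 2-fluorophenyl compound gives only a floor, an at least 1.3-fold lower number from compound 3 to compound 4 (0.13 log units; that floor lies within the scatter), and it cannot place these two compounds in order because the value of compound 3 is a limit of the assay and not a number: the limit of > 4 mg/kg in this assay, at which 1 of the 4 values shown sits.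

The compounds shown leave open how an unsubstituted phenyl ring would compare with cyclohexyl, which would separate the effect of changing the ring from that of the chloro and ethoxy groups on it. They also leave open whether a chloro or ethoxy group on the cyclohexyl ring, a smaller cyclopentyl ring or a piperidine ring, with its ring amine, would bring the number closer to that of compound 1.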